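Hydrazones of a shared quinazolinone core in a hemolysis assay

The compounds below may be only part of what the source reports. "The series", "measured", "known", "first", "only" and "open" are said of these compounds alone.

Measured so far:
Compound 1, `O=C(CCc1nc2ccccc2c(=O)[nH]1)N/N=C/c1ccc(O)c(O)c1`, in a functional assay on cells (Erythrocyte, Homo sapiens) for inhibition, read by spectrophotometry and hemolysis, with a stated time of 10 min (on this read-out higher numbers stand for weaker inhibition and lower numbers for stronger inhibition), gives 255000000 nM.
Compound 2, `O=C(CCc1nc2ccccc2c(=O)[nH]1)N/N=C/c1ccc(Cl)cc1`, gives 84000000 nM.
Compound 3, `O=C(CCCc1nc2ccccc2c(=O)[nH]1)N/N=C/c1ccc(Cl)cc1`, gives 67000000 nM.

Compounds 2 and 3 share a core whose difference is not broken down here. Their numbers lie within the usual scatter of each other, so no order between them can be claimed. Compound 1 stands higher than both beyond the scatter. From compound 2 to compound 1 the change is 3,4-dihydroxyphenyl in place of 4-chlorophenyl on a carbon with a double bond to nitrogen, and that step was a 3.0-fold higher number from compound 2 to compound 1 (0.48 log units; beyond the scatter).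

Compound 4, `O=C(CCCc1nc2ccccc2c(=O)[nH]1)N/N=C/c1ccc(O)c(O)c1`, is not yet measured. Among the measured compounds shown here, it differs from compound 3 by 3,4-dihydroxyphenyl in place of 4-chlorophenyl on a carbon with a double bond to nitrogen, the same change as from compound 2 to compound 1, which is the only other place this change occurs in the set. Since the step from compound 2 to compound 1 was a 3.0-fold higher number from compound 2 to compound 1 (0.48 log units; beyond the scatter), a similar step is expected from compound 3 to compound 4, estimated at a 3.0-fold higher number from compound 3 to compound 4 (0.47 log units; beyond the scatter). Compound 4 is therefore expected to give about 200000000 nM in this assay, likely between 100000000 nM and 400000000 nM.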

Compound 4, half-maximal inhibitory concentration in the Erythrocyte assay: 300000000 nM
For compound 4 the middle estimate is 1.5-fold (0.18 log units) below the measured one, and the stated range covers the measured number.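

In the Erythrocyte assay compound 3 gives 67000000 nM and compound 4 gives 300000000 nM; the replacement of 4-chlorophenyl by 3,4-dihydroxyphenyl gave a 4.5-fold higher number from compound 3 to compound 4 (0.65 log units; beyond the scatter), and the step agrees with the earlier one: the same change on two cores in the Erythrocyte assay, a 3.0-fold higher number (0.48 log units; beyond the scatter) from compound 2 to compound 1 and a 4.5-fold higher number (0.65 log units; beyond the scatter) from compound 3 to compound 4, 1.5-fold (0.17 log units) apart, within the scatter of two such steps. In this assay, then, the change carried from the core of compound 2 to the core of compound 3 in direction and, within the scatter, in size, although only these two pairs support this and they say nothing about any other core. Nor does the agreement extend to every read-out, since in a physicochemical assay, read by spectrophotometry, with a stated time of 30 min (on this read-out lower numbers stand for stronger inhibition and higher numbers for weaker inhibition), the same pair runs the other way, with a 3.7-fold lower number from compound 3 to compound 4 (0.57 log units; beyond the scatter). In the physicochemical assay compound 3 gives 353000000 nM and compound 4 gives 95000000 nM.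

The compounds shown leave open whether the step would persist on a core with a longer chain, and whether the opposite direction seen in the physicochemical assay would also appear on the core of compound 2. They also leave open how a carboxylic acid or an amine in place of 4-chlorophenyl would behave in either assay.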